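The compounds below may be only part of what the source reports. "The series", "measured", "known", "first", "only" and "open" are said of these compounds alone.

Measured compounds in a functional assay on M21 cells (Homo sapiens) for cytotoxicity, read by sulforhodamine B assay, with a stated time of 48 h; on this read-out higher numbers stand for weaker inhibition and lower numbers for stronger inhibition:
Compound 1 `O=C(NCCCCl)Nc1cccc(S(=O)(=O)Oc2ccc(O)cc2)c1` gives 49000 nM.
Compound 2 `Cc1ccccc1OS(=O)(=O)c1ccc(NC(=O)NCCCCl)cc1` gives 25000 nM.
Compound 3 `CCNC(=O)Nc1cccc(S(=O)(=O)Oc2ccc(O)cc2)c1` gives 42000 nM.

Compound 3 differs from compound 1 by a single change, (hydrogen in place of chloromethyl on a saturated chain carbon, two bonds along the chain from an amide-type nitrogen). That step, a 1.2-fold lower number from compound 1 to compound 3 (0.07 log units; within the scatter), left the read-out essentially where it was. Compound 2 rests on a different core; how the core of compound 2 differs from the core of compound 1 is not broken down here. The unmeasured compound 4 `CCNC(=O)Nc1ccc(S(=O)(=O)Oc2ccccc2C)cc1` stands to compound 2 as compound 3 stands to compound 1, carrying the same change, (hydrogen in place of chloromethyl on a saturated chain carbon, two bonds along the chain from an amide-type nitrogen), at the same place. The expectation for compound 4 rests on compound 1, whose step a 1.2-fold lower number from compound 1 to compound 3 (0.07 log units; within the scatter) stayed within the scatter. The expected step is therefore small, a 1.1-fold lower number from compound 2 to compound 4 (0.04 log units; within the scatter). Compound 4 is estimated at 23000 nM in this assay, with a likely range from 9000 nM to 60000 nM.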

Compound 4, half-maximal inhibitory concentration: 3100 nM
The estimate for compound 4 lay 7.4-fold (0.87 log units) above the measured number; the measured number lies below the stated range.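

In this assay, replacing 3-chloropropyl with ethyl gives an 8.1-fold lower number from compound 2 to compound 4 (0.91 log units; beyond the scatter). The outcome of this change therefore does not carry over unchanged from one core to the other: the same change on two cores in this assay, a 1.2-fold lower number (0.07 log units; within the scatter) from compound 1 to compound 3 and an 8.1-fold lower number (0.91 log units; beyond the scatter) from compound 2 to compound 4, 6.9-fold (0.84 log units) apart, beyond the scatter of two such steps. These two pairs show that the size of the step depends on the core it is made on, but they do not show which part of the core matters, or why.

Still open, going by these compounds, is whether propyl, a chain of the same length without chlorine, would match ethyl on the core of compound 2, which would separate losing the chlorine from shortening the chain. An amine at the chain end would test a different replacement for the chlorine.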